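The compounds below may be only part of what the source reports. "The series", "measured", "known", "first", "only" and "open" are said of these compounds alone.

Of the compounds shown here, two built on the same core have been measured in a functional assay on the whole organism (strain Wistar) with Rattus norvegicus as the target, with a stated time of 15 days, at a dose of 10 mg/kg by the oral route; on this read-out higher numbers stand for a stronger effect at the one dose given and lower numbers for a weaker effect. Compound 1 `O=C1NC(=O)/C(=C/c2ccc(OCc3csc(-c4ccccc4)n3)cc2)S1` gives 21.7% in this assay. Compound 2 `O=C1NC(=O)/C(=C/c2ccc(OCCSc3nnc(-c4ccccc4)[nH]3)cc2)S1` gives 19.2% in this assay, and these two values lie within the usual scatter of each other, so no difference between them can be read from the numbers. Compound 3 `Cc1ccc(-c2nnc(SCCOc3ccc(/C=C4\SC(=O)NC4=O)cc3)[nH]2)cc1` has not yet been measured. It differs from compound 2 in one place: methyl in place of hydrogen on an aromatic carbon. For the measured compounds named here, no pair of measured compounds shows a change of this kind, so what follows rests on expectation alone. The step of a number 0.8 percentage points higher from compound 2 to compound 3 (within the scatter) is expected to stay within the scatter, meaning neither a clear gain nor a clear loss. Compound 3 is therefore estimated to give 20% in this assay, with a likely range from 8% to 34%.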

Compound 3, a percentage reported as activity, at one dose (the size of the read-out at that dose, not a potency): 21.7%
For compound 3 the middle estimate is 1.7 percentage points below the measured one; the measured number falls inside the stated range.
By their numbers in this assay, from the lowest: compounds 2, 1 and 3 (each within the scatter of the next).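

For the compounds shown here, compound 3 gives the first direct reading of a change on the outer six-membered aromatic ring, where phenyl becomes 4-methylphenyl. In this assay the change is a number 2.5 percentage points higher from compound 2 to compound 3 (within the scatter), so a methyl group on this ring, para to a large group, brings neither a clear gain nor a clear loss at the one dose given. Nothing available here bears on why the step is this small.

This single step says nothing about how a different group at the same place, such as a methoxy group, a chlorine atom or an amine, would behave. It also leaves open whether the same methyl group would have so little effect on the ring of compound 1, or at other places on the ring of compound 2.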